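The source may hold more compounds than are shown below. What is called first, only, known or untested is meant among the compounds shown, and "the series" means these compounds.

Measured so far: compound 1, `C=CCN(CCCC(=O)O)C(=O)/C(C)=C/c1ccc(C(=O)Oc2ccc(C(=N)N)cc2)cc1`, in an in vitro ADME assay on a cell-free system (plasma) for pharmacokinetics (a lower number here means that the compound disappears faster, a higher number that the compound lasts longer), gives > 1 h, which is a limit of the assay and not a number. Compound 2, `CCOC(=O)CN(C(=O)/C(C)=C/c1ccc(C(=O)Oc2ccc(C(=N)N)cc2)cc1)C1CCCC1`, gives in this assay < 0.0834 h, likewise a limit. Compound 3, `C/C(=C\c1ccc(C(=O)Oc2ccc(C(=N)N)cc2)cc1)C(=O)N(CC(=O)O)C1CCCC1`, gives in this assay 0.383 h.

Going by the values given here, compound 3 therefore holds the only plain number among the three; the other two values sit at the limits (the limit of > 1 h in this assay, at which 1 of the 3 values shown sits, and (the limit of < 0.0834 h in this assay, at which 1 of the 3 values shown sits)). Compound 4, `C=CCN(CCC(=O)OCC)C(=O)/C(C)=C/c1ccc(C(=O)Oc2ccc(C(=N)N)cc2)cc1`, is to be measured in this assay. It differs from compound 3 in one place: allyl(2-(ethoxycarbonyl)ethyl)amino in place of (carboxymethyl)(cyclopentyl)amino on a carbonyl carbon.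

Among the compounds with values here, two measured steps bear on this. Within the data shown here, the first is the change of the amine substituents, an at least 2.6-fold lower number from compound 1 to compound 3 (0.41 log units; beyond the scatter), which runs toward the allyl-bearing side of compound 1 with a higher number. The second is the ethyl ester against the free acid, an at least 4.5-fold higher number from compound 2 to compound 3 (0.66 log units; beyond the scatter), where the ester of compound 2 gave the lower number. Compound 4 carries both an allyl group and an ethyl ester, so the two steps pull in opposite directions; the ester step is the larger, and its limit leaves its true size open. A lower number is therefore expected for compound 4, with the step of a 3.8-fold lower number from compound 3 to compound 4 (0.58 log units; beyond the scatter). Compound 4 is estimated at 0.1 h, in the range 0.03 h to 0.5 h.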

Compound 4, half-life: < 0.0167 h
Compound 4 was reported as a limit (the forecaster's own chance of this, stated with the estimate: 45%); middle value at least 5.9-fold (0.77 log units) from the limit.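

Compound 4 stands at a limit of this assay and not at a number: the limit of < 0.0167 h in this assay, at which 1 of the 4 values shown sits. On the allyl-bearing amide, ethoxycarbonyl in place of carboxymethyl on a saturated chain carbon gives an at least 59-fold lower number from compound 1 to compound 4 (1.77 log units; beyond the scatter), so the ester side goes with the lower number on this amine too, as it did on the cyclopentyl amine of compound 2 and compound 3. The full exchange on the carbonyl carbon gives an at least 22-fold lower number from compound 3 to compound 4 (1.36 log units; beyond the scatter), so the allyl group, which compound 1 had suggested might raise the number, does not offset the ester here.

As far as these compounds go, both steps are open-ended, so their true size stays unknown. The shorter chain and the ester also arrive together in compound 4; an allyl amide with a 2-carboxyethyl group, the free carboxylic acid on that same chain, would separate them.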